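Solubility notes: from compound 1 toward compound 3

The compounds below may be only part of what the source reports. "The series", "measured", "known", "first", "only" and "open" are said of these compounds alone.

Two compounds in this set carry a reading in a physicochemical assay for solubility, read by spectrophotometry, in phosphate buffer, with a stated time of 2 h, at pH 7.4; on this read-out lower numbers stand for lower solubility and higher numbers for higher solubility. Compound 1 `COc1ccc2[nH]c(C(=O)N3CC(=O)N(Cc4ccccc4)[C@@H](CN4CCC(OC)CC4)C3)cc2c1` sits at a limit of the assay: in this assay compound 1 gives > 25000 nM, which is a limit and not a number. Its standing therefore rests on the limit of > 25000 nM in this assay, at which 1 of the 2 values shown sits, rather than on a measured point. Compound 2 `COc1ccc2[nH]c(C(=O)N3CC(=O)N(Cc4cc5ccccc5[nH]4)[C@@H](Cc4ccccc4)C3)cc2c1` is the other measured member; in this assay compound 2 gives 11000 nM. These two are not joined by a single-point change, so their values stand side by side only.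

Compound 3 `COc1ccc2[nH]c(C(=O)N3CC(=O)N(Cc4ccccc4)[C@@H](CN4CCc5ccccc5C4)C3)cc2c1` has not been measured. It differs from compound 1 in one place: 1,2,3,4-tetrahydroisoquinolin-2-yl in place of 4-methoxypiperidin-1-yl on a saturated chain carbon bound to a saturated ring carbon. For the measured compounds named here, no measured pair in this set covers such a change, so nothing here fixes the size of the step. A drop in solubility beyond the usual scatter is nonetheless expected, and the estimated step of an at least 3.1-fold lower number from compound 1 to compound 3 (0.49 log units; beyond the scatter) is taken to run downward. For compound 3 the expected reading in this assay is 8000 nM, with an estimated range from 2000 nM to 25000 nM.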

Compound 3, solubility: 9000 nM
Compound 3: middle estimate off by 1.1-fold (0.05 log units), on the low side; the measured number falls inside the stated range.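

In this assay, the first step read at this position sits on a saturated chain carbon bound to a saturated ring carbon, where 1,2,3,4-tetrahydroisoquinolin-2-yl takes the place of 4-methoxypiperidin-1-yl: an at least 2.7-fold lower number from compound 1 to compound 3 (0.44 log units; beyond the scatter) is a step beyond the usual scatter and runs downward. For compound 1, the reading of > 25000 nM is a limit and not a number. The step therefore fixes a direction and a minimum size for this change, but not its full size: the limit of > 25000 nM in this assay, at which 1 of the 3 values shown sits.

The compounds shown leave open how much of the step goes with the added six-membered aromatic ring and how much with the departure of the methoxy group; plain piperidin-1-yl on the same chain carbon would separate the two, and a morpholin-4-yl group there would show whether a ring oxygen in another place reads differently. Also open, as far as these compounds go, is whether the step carries over to other groups on the shared core, as compound 2 differs from compound 1 and compound 3 in more than one place and offers no single-point comparison.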